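A Dimethylamino Swap on a Potent Tricyclic Core

This account rests on a few compounds, and the source may have more. Where it says the series, first, only, none or still open, it means among the compounds named here.

Measured compounds:
Compound 1, `CCCc1ccc(N2C(=O)NC3(CSC4=C3C(=O)c3ncccc3C4=O)C2=O)cc1`: in a functional assay on CCRF-SB cells (Homo sapiens) for antiproliferative activity, read by MTT assay, with a stated time of 96 h (on this read-out lower numbers stand for stronger inhibition and higher numbers for weaker inhibition), compound 1 gives 2 nM
Compound 2, `O=C1NN(c2ccccc2)C(=O)C2(CSC3=C2C(=O)c2ncccc2C3=O)N1`: in this assay compound 2 gives 39 nM

Of the compounds shown here, two with the shared core have been measured so far. Compound 1 stands lowest of the two, which on this read-out means the stronger inhibition of cell growth. Compound 2, which carries a plain phenyl on a different kind of ring in place of the propyl-bearing phenyl, gives a clearly higher number, and that gap lies beyond the usual scatter of repeated measurements.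

The next compound to be measured is compound 3, `CN(C)c1ccc(N2C(=O)NC3(CSC4=C3C(=O)c3ncccc3C4=O)C2=O)cc1`. It differs from compound 1 in one place: dimethylamino in place of propyl on an aromatic carbon. The group that enters is the same size in heavy atoms as the one that leaves and sits on the same aromatic carbon, para to a large group, but it brings one hydrogen-bond acceptor where there was none.

For the measured compounds named here, no pair of measured compounds shows this particular change, so there is no direct guide to its effect. The expectation for this assay is a small step, likely within or only just beyond the scatter, with a slight lean toward a higher number. Compound 3 is therefore estimated at 4 nM, with a range from 1 nM to 15 nM, which corresponds to an expected step of a 2.0-fold higher number from compound 1 to compound 3 (0.30 log units; within the scatter).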

Compound 3, half-maximal inhibitory concentration: 1 nM
Estimate against measurement, compound 3: 4.0-fold (0.60 log units) above, within the range that was stated.
By their numbers in this assay, from the lowest: compounds 3 and 1 (each within the scatter of the next); then compound 2.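

In this assay, placing dimethylamino where propyl stood gives a 2.0-fold lower number from compound 1 to compound 3 (0.30 log units; within the scatter), so compound 1 and compound 3 cannot be told apart on this read-out. For the compounds shown here, this is the first sign that this aromatic carbon accepts a nitrogen-bearing group, with a hydrogen-bond acceptor where there was none, while the value stays in the same low range. No measurement shown here bears on what lies behind this result.

As far as these compounds go, both groups have the same number of heavy atoms, so what a longer chain such as hexyl, a primary amine or a carboxylic acid would do on this same carbon remains open. The pair also cannot say whether the acceptor itself matters to the activity, and a group such as methoxy or isopropyl on this carbon would be needed to begin to separate its contribution from that of the group's shape.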